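The source may report more compounds than this note shows. Statements on the series, on what has been measured and on what is new or still open speak of the compounds shown alone.

In an ADME assay on microsomes from liver (Homo sapiens) for metabolic stability (a higher number here means faster removal of the compound, a lower number slower removal), compound 1 `Cc1ccc([C@H](C)NC(=O)Cn2nnc3ccccc3c2=O)cc1` gives < 9.9 mL/min/kg as its reading, which is a limit of the assay and not a number. Going by the values given here, compound 2 `Cc1ccc([C@H](C)NC(=O)Cn2nnc3ccccc3c2=O)c(C)c1` gives 33 mL/min/kg as the only true number so far. Among the compounds with values here, the single measured step is an at least 3.3-fold higher number from compound 1 to compound 2 (0.52 log units; beyond the scatter) and consists of methyl in place of hydrogen on an aromatic carbon. Going by these compounds, it rests on the limit of < 9.9 mL/min/kg in this assay, at which 1 of the 2 values shown sits, and its full size therefore stays open. Compound 3 `COc1cc(C)ccc1[C@H](C)NC(=O)Cn1nnc2ccccc2c1=O` keeps the shared core and alters that same carbon again: methoxy in place of methyl on an aromatic carbon (methoxy in place of methyl on an aromatic carbon, ortho to a large group, meta to a methyl group). Within the data shown here, no measured step covers methoxy at this carbon. Among the measured compounds shown here, with an at least 3.3-fold higher number from compound 1 to compound 2 (0.52 log units; beyond the scatter) as the only guide, compound 3 still carries a group there, so its number is expected to stay near that of compound 2 rather than fall back toward the limit. The expected change is a 1.3-fold lower number from compound 2 to compound 3 (0.12 log units; within the scatter) and it is estimated to lie within the scatter. The estimate for compound 3 is 25 mL/min/kg with an expected range from 11 mL/min/kg to 60 mL/min/kg in this assay for this compound.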

Compound 3, clearance: 30 mL/min/kg
The estimate for compound 3 lay 1.2-fold (0.08 log units) below the measured number; low and high end bracket the measured number.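

In this assay, methoxy in place of methyl at this carbon, ortho to a large group, gives a 1.1-fold lower number from compound 2 to compound 3 (0.04 log units; within the scatter), so a second kind of group here reads the same as methyl within the scatter. Set against the hydrogen of compound 1, methoxy gives an at least 3.0-fold higher number from compound 1 to compound 3 (0.48 log units; beyond the scatter), which means the higher number is now seen with two different groups at this carbon rather than one, and no compound shown goes against it. The reading of compound 1 is a limit and not a number, so the full size of this step stays open: the limit of < 9.9 mL/min/kg in this assay, at which 1 of the 3 values shown sits.

Going by these compounds, only methyl and methoxy appear at this carbon, so it remains open whether an amine, a carboxylic acid or a longer chain such as ethoxy would read with compound 2 and compound 3 or fall back toward compound 1. Also open, on these data alone, is whether methoxy on another carbon of the same ring would move the number at all, and what the methyl group shared by all three compounds contributes to the clearance seen here.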